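The source may hold more compounds than are shown below. What is called first, only, known or untested is meant among the compounds shown, and "the series" means these compounds.

Measured compounds in an assay on artery for agonist activity at transient receptor potential cation channel subfamily V member 1 (Rattus norvegicus); a lower number here means that less compound is needed, a higher number that more compound is needed for the effect:
compound 1 `CCCCC/C=C\C/C=C\C/C=C\C/C=C\CCCC(=O)Nc1ccc(OC)c(O)c1` gives 3.16 nM
compound 2 `CCCCC/C=C\C/C=C\C/C=C\C/C=C\CCCC(=O)Nc1ccc2[nH]ncc2c1` gives 12.6 nM

Of these two numbers compound 2 holds the higher one: a 4.0-fold higher number from compound 1 to compound 2 (0.60 log units; beyond the scatter). Compound 3 `CCCCC/C=C\C/C=C\C/C=C\C/C=C\CCCC(=O)NCc1ccc2[nH]ncc2c1` has not yet been measured in this assay. It differs from compound 2 in one place: (1H-indazol-5-yl)methyl in place of 1H-indazol-5-yl on an amide-type nitrogen. Among the compounds with values here, no measured step bears directly on this change; the only step in hand, from compound 1 to compound 2, concerns the exchange of one aryl group for another on the same amide nitrogen, and its size was modest. Nothing in the data shows what the insertion of a methylene between the amide nitrogen and the indazole does. Compound 3 is therefore expected to stay close to compound 2, with a wide band around that estimate: a 1.2-fold higher number from compound 2 to compound 3 (0.08 log units; within the scatter). The expected value for compound 3 is 15 nM, within a range of 3 nM to 80 nM.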

Compound 3, half-maximal effective concentration: 3.98 nM
Estimate against measurement, compound 3: 3.8-fold (0.58 log units) above; the measured number falls inside the stated range.
By their numbers in this assay, from the lowest: compounds 1 and 3 (each within the scatter of the next); then compound 2.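

In this assay, the added methylene on the amide-type nitrogen is not without effect: (1H-indazol-5-yl)methyl in place of 1H-indazol-5-yl gives a 3.2-fold lower number from compound 2 to compound 3 (0.50 log units; beyond the scatter) and so reverses most of the loss seen with the earlier aryl exchange. With this methylene in place, the indazole compound no longer stands apart from the 3-hydroxy-4-methoxyphenyl compound, since the comparison gives a 1.3-fold higher number from compound 1 to compound 3 (0.10 log units; within the scatter) in this read-out. Nothing available here gives a reason for this shift.

The compounds shown leave open whether a longer chain, such as 2-(1H-indazol-5-yl)ethyl, on the same nitrogen would keep this level. They also leave open whether a 3-hydroxy-4-methoxybenzyl group would respond to the added methylene as the indazole does.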